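This account rests on a few compounds, and the source may have more. Where it says the series, first, only, none or still open, it means among the compounds named here.

Measured so far:
Compound 1, `c1ccc(CCCCNc2nc(NCCCCc3ccccc3)c3cccnc3n2)cc1`, in a functional assay on MDA-MB-231 cells (Homo sapiens) for cytotoxicity, read by neutral red uptake, with a stated time of 72 h (a higher number here means a weaker inhibitor, a lower number a stronger inhibitor), gives 1100 nM.
Compound 2, `CCCCNc1nc(SCC)nc2ncccc12`, in this assay gives 9200 nM.

Compound 2 stands at the higher of the two numbers, which means it is the weaker of the two; compound 1 sits far enough below it that the gap is beyond the usual scatter. The two structures differ in many places at once, so their values say nothing about any single change.

Compound 3, `CCCCCCNc1nc(SCC)nc2ncccc12`, has not yet been measured in this assay. It differs from compound 2 by ethyl in place of hydrogen on a saturated chain carbon, four bonds along the chain from a nitrogen on an aromatic ring. Going by the values given here, no pair of measured compounds shows the effect of such a chain extension on its own. The expectation is a modest move toward a lower number, around the edge of the scatter, estimated as a 1.7-fold lower number from compound 2 to compound 3 (0.22 log units; within the scatter). Compound 3 is therefore expected to give about 5500 nM, with a plausible range from 1800 nM to 16000 nM.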

Compound 3, half-maximal inhibitory concentration: 1400 nM
The estimate for compound 3 lay 3.9-fold (0.59 log units) above the measured number; the measured number lies below the stated range.
By their numbers in this assay, from the lowest: compounds 1 and 3 (each within the scatter of the next); then compound 2.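

Putting ethyl in place of hydrogen on a saturated chain carbon, four bonds along the chain from a nitrogen on an aromatic ring, gives a 6.6-fold lower number from compound 2 to compound 3 (0.82 log units; beyond the scatter) in this assay, the first effect here that can be traced to one change. This position therefore responds to a change that adds only carbon: ethyl brings 2 heavy atoms, no ring and no net charge, yet the step lies beyond the usual scatter. No measurement here bears on why the number moves with this change.

From the compounds shown here alone, whether a longer chain at this position would move the number further in the same direction remains open, as does the effect of placing an amine or a carboxylic acid there. A single step also cannot show whether the same change would have a similar effect on the core of compound 1.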